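A few compounds are considered here, and "the series" means these few. Any claim that something is new, unique, unknown or untested is made for them only; others in the source may bear on it.

Measured so far in an ADME assay on Huh-7 cells (Homo sapiens) for cytotoxicity, with a stated time of 72 h (on this read-out lower numbers stand for higher toxicity in this test and higher numbers for lower toxicity in this test), each value being a limit and not a number:

- compound 1 `CC(C)CCn1nc(C2CCC2)c(O)c(C2=NS(=O)(=O)c3cc(NS(C)(=O)=O)ccc3N2)c1=O` gives > 33000 nM
- compound 2 `CC(C)CCn1nc(CC2CCC2)c(O)c(C2=NS(=O)(=O)c3cc(NS(C)(=O)=O)ccc3N2)c1=O` gives > 33000 nM
- compound 3 `CC(C)CCn1nc(C2=CCCC2)c(O)c(C2=NS(=O)(=O)c3cc(NS(C)(=O)=O)ccc3N2)c1=O` gives > 1000 nM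

Compound 3 stands at the limit of > 1000 nM in this assay, at which 1 of the 3 values shown sits, and so has no exact place on the scale. Compound 1 and compound 2 stand at the limit of > 33000 nM in this assay, at which 2 of the 3 values shown sit, instead.

Compound 4 `CC(C)CCn1nc(CCC(F)(F)F)c(O)c(C2=NS(=O)(=O)c3cc(NS(C)(=O)=O)ccc3N2)c1=O` carries 3,3,3-trifluoropropyl in place of cyclopent-1-en-1-yl on an aromatic carbon, next to the ring nitrogen and ortho to a hydroxy group, as counted here: 3,3,3-trifluoropropyl in place of cyclopent-1-en-1-yl on an aromatic carbon.

Three measured changes at this same place bear on it. They are a step that the two limits leave unreadable from compound 1 to compound 2, a step that the two limits leave unreadable from compound 1 to compound 3 and a step that the two limits leave unreadable from compound 2 to compound 3. Among the compounds with values here, none offers a size to carry over, so no step of known size or direction is expected in this assay, and compound 4 is expected to end as another limit rather than a number. The step estimated here is a step that the limit leaves unreadable from compound 3 to compound 4 and it is only loosely held.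

For compound 4 the estimated value is 33000 nM, with an expected range from 10000 nM to 100000 nM.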

Compound 4, half-maximal cytotoxic concentration: > 33000 nM
Compound 4: only a limit was reported (the forecaster's own chance of this, stated with the estimate: 85%); the middle value sits exactly at the limit.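

In this assay compound 4 gives > 33000 nM, a limit and not a number. Within the data shown here, no step from compound 1, compound 2 or compound 3 to compound 4 can be read. The compounds shown leave open whether changing this group alters the read-out at all.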